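Swapping Phenyl for 2-Fluoropyridin-3-yl: An Expected Outcome

The compounds below may be only part of what the source reports. "The series", "measured", "known", "first", "only" and "open" are said of these compounds alone.

Measured compounds:
compound 1, `O=C(Nc1ccc(F)cc1)c1ccnc2cc(Br)ccc12`, gives > 20000 nM
compound 2, `O=C(Nc1cccc(F)c1)c1cc(=O)[nH]c2cc(-c3ccccc3)ccc12`, gives > 20000 nM

In a functional assay on KYSE-70 cells for antiproliferative activity against KYSE-70 cell line (Homo sapiens), read by MTT assay, with a stated time of 72 h (a lower number here means a stronger inhibitor, a higher number a weaker inhibitor), compound 1 reaches only the assay limit, > 20000 nM. Compound 2 likewise reaches only the limit, > 20000 nM. Both results sit at the limit of > 20000 nM in this assay, at which 2 of the 2 values shown sit, so neither compound yields a number, and nothing can be said about any difference between them.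

Compound 3, `O=C(Nc1cccc(F)c1)c1cc(=O)[nH]c2cc(-c3cccnc3F)ccc12`, differs from compound 2 in one place:
2-fluoropyridin-3-yl in place of phenyl on an aromatic carbon

Among the measured compounds shown here, no measured step resembling this change exists here, so the expectation rests only on the position of compound 2 at the limit. The step of a number no higher from compound 2 to compound 3 (the limit leaves the size open) is expected to be small and without a clear direction. Compound 3 is therefore estimated at 20000 nM, within 5000 nM to 60000 nM, with a limit rather than a number the most probable report.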

Compound 3, half-maximal inhibitory concentration: > 20000 nM
Compound 3: a limit, no number; the forecaster's own chance of this, stated with the estimate: 70%; the middle value lies on the limit itself.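

Compound 3, like compound 2, gives only a limit and no number, so the step between them cannot be read: the limit of > 20000 nM in this assay, at which 3 of the 3 values shown sit.

What the compounds shown leave open is whether swapping phenyl for 2-fluoropyridin-3-yl changes activity at all.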